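A Sulfonyl Group Comes to Compound 2

The source may hold more compounds than are shown below. What is called first, only, known or untested is meant among the compounds shown, and "the series" means these compounds.

In an ADME assay on L02 cells (Homo sapiens) for cytotoxicity, read by MTT assay, with a stated time of 24 h (on this read-out lower numbers stand for stronger inhibition and higher numbers for weaker inhibition), compound 2 `O=C1/C(=C/c2cccnc2)CNC/C1=C\c1ccccc1F` gives 15900 nM and sits level, within the usual scatter, with compound 1 `CN1C/C(=C\c2ccncc2)C(=O)/C(=C/c2cc([N+](=O)[O-])ccc2F)C1` at 17600 nM on the same scale. The change from compound 2 to compound 3 `O=C1/C(=C/c2cccnc2)CN(S(=O)(=O)c2ccc(Cl)cc2)C/C1=C\c1ccccc1F` is (4-chlorophenyl)sulfonyl in place of hydrogen on an amine nitrogen in a ring and amounts to (4-chlorophenyl)sulfonyl in place of hydrogen on an amine nitrogen in a ring. Going by the values given here, no measured pair shows such a change, so only a modest move towards stronger inhibition is expected in this assay as an estimated 1.8-fold lower number from compound 2 to compound 3 (0.25 log units; within the scatter) that may still lie inside the scatter. For compound 3 the expected value is 9000 nM with an estimated range from 3000 nM to 27000 nM in this test.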

Compound 3, half-maximal inhibitory concentration: > 20000 nM
Compound 3 gave a limit, no number; the forecaster's own chance of this, stated with the estimate: 10%; middle value at least 2.2-fold (0.34 log units) away from the limit.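

Going by these compounds alone, the first measured change on the amine nitrogen in the ring gives, in this assay, an at least 1.2-fold higher number from compound 2 to compound 3 (0.09 log units; that floor lies within the scatter). Placing (4-chlorophenyl)sulfonyl at this position therefore brings no sign of stronger inhibition, although the step alone does not establish weaker inhibition. Compound 3 gives a limit rather than a number: the limit of > 20000 nM in this assay, at which 1 of the 3 values shown sits.

As far as these compounds go, how far compound 3 lies past that limit remains unknown. Also open, from the compounds shown here alone, is whether a smaller group on this nitrogen, such as acetyl or methylsulfonyl, would behave in the same way.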